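Two chloro steps on related cores, acid ceramidase inhibition

The source may report more compounds than this note shows. Statements on the series, on what has been measured and on what is new or still open speak of the compounds shown alone.

Compound 1 `O=C(c1ccccc1)c1ccc2c(c1)oc(=O)n2C(=O)NCCCCc1ccccc1` and compound 2 `O=C(NCCCCc1ccccc1)n1c(=O)oc2cc(Cl)ccc21` differ in their cores by chloro in place of benzoyl on an aromatic carbon. In an assay on HEK293 cells for inhibition of acid ceramidase (Homo sapiens), with a stated time of 10 min (a higher number here means a weaker inhibitor, a lower number a stronger inhibitor), compound 1 gives 29 nM and compound 2 gives 33 nM, a step of a 1.1-fold higher number from compound 1 to compound 2 (0.06 log units; within the scatter). Compound 3 `O=C(c1ccc(Cl)cc1)c1ccc2c(c1)oc(=O)n2C(=O)NCCCCc1ccccc1` arises from compound 1 through (chloro in place of hydrogen on an aromatic carbon); in this assay compound 3 gives 14 nM, and the step is a 2.1-fold lower number from compound 1 to compound 3 (0.32 log units; beyond the scatter). Compound 4 `O=C(NCCCCc1ccccc1)n1c(=O)oc2cc(Cl)c(Cl)cc21` arises from compound 2 through (chloro in place of hydrogen on an aromatic carbon). This is the same kind of change, not the same: in compound 3 the chloro stands para to a large group, whereas in compound 4 it stands on a ring that is part of a fused or bridged system of two rings, ortho to a chloro group, meta to a fused ring and para to a fused ring. Going by the values given here, only one measured instance of this change exists, so the expected step of a 1.7-fold lower number from compound 2 to compound 4 (0.22 log units; within the scatter) is set near a 2.1-fold lower number from compound 1 to compound 3 (0.32 log units; beyond the scatter) and rests on that step alone. Compound 4 is accordingly expected to give 20 nM in this assay, estimated between 8 nM and 50 nM.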

Compound 4, half-maximal inhibitory concentration in the acid ceramidase assay: 18 nM
For compound 4 the middle estimate is 1.1-fold (0.05 log units) above the measured one, within the range that was stated.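

In the acid ceramidase assay compound 2 gives 33 nM and compound 4 gives 18 nM; the step for the added chloro is a 1.8-fold lower number from compound 2 to compound 4 (0.26 log units; within the scatter), and this step does not differ from the earlier one on the other core: the same change on two cores in the acid ceramidase assay, a 2.1-fold lower number (0.32 log units; beyond the scatter) from compound 1 to compound 3 and a 1.8-fold lower number (0.26 log units; within the scatter) from compound 2 to compound 4, 1.1-fold (0.05 log units) apart, within the scatter of two such steps. The change therefore has a similar size on these two cores, but the step on compound 2 alone stays within the scatter, and the chloro stands in a different place in compound 3 and compound 4, so two pairs give no general rule for the series. In a physicochemical assay for metabolic stability, read by HPLC, in phosphate buffer, at pH 7.4, tested at 10 uM (a higher number here means that the compound lasts longer, a lower number that the compound disappears faster), compound 2 gives 0.967 h and compound 4 gives 0.917 h, and the step is a 1.1-fold lower number from compound 2 to compound 4 (0.02 log units; within the scatter).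

From the compounds shown here alone, whether a fluoro, a methoxy or a nitrile in place of the added chloro would give a step of similar size remains open. Going by these compounds alone, also open is whether the chloro step holds with a longer chain in place of the one these compounds share.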